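The source may hold more compounds than are shown below. What is called first, only, known or untested is meant among the compounds shown, and "the series" means these compounds.

Measured compounds in the series:

- compound 1, `Cc1ccc2nc(Nc3nc(Nc4ccc(S(N)(=O)=O)cc4)ncc3C)sc2c1`, 3870 nM
- compound 2, `Cc1cnc(Nc2ccc(S(N)(=O)=O)cc2)nc1Nc1nc2ccc(Cl)cc2s1`, 2520 nM
- compound 3, `Cc1ccc2nc(Nc3ccnc(Nc4ccc(S(C)(=O)=O)cc4)n3)sc2c1`, 1750 nM

All three were run in a functional assay on HCT-116 cells (Homo sapiens) for antiproliferative activity, read by MTT assay, with a stated time of 48 h; on this read-out higher numbers stand for weaker inhibition and lower numbers for stronger inhibition. Compound 1 and compound 2 share a core and differ in one place: chloro in place of methyl on an aromatic carbon. That change gave a 1.5-fold lower number from compound 1 to compound 2 (0.19 log units; within the scatter). Compound 3 carries a different core; how the core of compound 3 differs from the core of compound 1 is not broken down here, and the two values stand as they are, compound 1 at 3870 nM against compound 3 at 1750 nM. Compound 2 and compound 3 lie within the scatter of each other.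

Compound 4, `CS(=O)(=O)c1ccc(Nc2nccc(Nc3nc4ccc(Cl)cc4s3)n2)cc1`, is not yet measured. It differs from compound 3 by chloro in place of methyl on an aromatic carbon, the same change seen from compound 1 to compound 2, at a place described in the same words. Among the measured compounds shown here, on the one earlier instance, a small step within the scatter, the expectation for compound 4 is a step of a 1.5-fold lower number from compound 3 to compound 4 (0.16 log units; within the scatter) in this assay, with the earlier step of a 1.5-fold lower number from compound 1 to compound 2 (0.19 log units; within the scatter) as its only basis. The estimate for compound 4 is thus 1200 nM, between 500 nM and 3000 nM.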

Compound 4, half-maximal inhibitory concentration: 1350 nM
Estimate against measurement, compound 4: 1.1-fold (0.05 log units) below; the measured number falls inside the stated range.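

In this assay, chloro in place of methyl on an aromatic carbon gives a 1.3-fold lower number from compound 3 to compound 4 (0.11 log units; within the scatter), and this step agrees with the earlier one: the same change on two cores in this assay, a 1.5-fold lower number (0.19 log units; within the scatter) from compound 1 to compound 2 and a 1.3-fold lower number (0.11 log units; within the scatter) from compound 3 to compound 4, 1.2-fold (0.07 log units) apart, within the scatter of two such steps

On these two pairs, the change carries from one core to the other with a step of matching size, and neither core stands apart. Both steps lie within the scatter, however, so neither pair on its own separates the change from repeat variation, and the agreement is one between two small steps rather than evidence of a reliable gain. Two cores in one cell line also give no general rule for the series, and these data give no reason for the match.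

The compounds shown carry only methyl or chloro at this place, so the effect of a larger change there, such as a methoxy group, an amine, a carboxylic acid or a longer chain, stays open. Also open, as far as these compounds go, is whether a group giving a step beyond the scatter on one core would give a step of the same size on the other.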